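The source may report more compounds than this note shows. Statements on the series, on what has been measured and on what is new or still open speak of the compounds shown alone.

Measured in a functional assay on HeLa cells (Homo sapiens) for antiproliferative activity, read by CCK-8 assay, with a stated time of 72 h, tested at 2 uM; on this read-out higher numbers stand for a stronger effect at the one concentration tested and lower numbers for a weaker effect:
compound 1 `Nc1ccccc1NC(=O)c1ccc(CSC(=S)N2CCN(c3ccc(Cl)cc3)CC2)cc1`: 51.2%
compound 2 `Nc1ccccc1NC(=O)c1ccc(CSC(=S)N2CCN(c3ccccc3)CC2)cc1`: 62.2%
compound 3 `COc1ccc(N2CCN(C(=S)SCc3ccc(C(=O)Nc4ccccc4N)cc3)CC2)cc1`: 39.4%

Compound 3 stands lowest of the three numbers in this assay; the steps of a number 11.8 percentage points lower from compound 1 to compound 3 (beyond the scatter) and a number 22.8 percentage points lower from compound 2 to compound 3 (beyond the scatter) both run downward into it and both exceed the scatter. Compound 4 `Nc1ccccc1NC(=O)c1ccc(CSC(=S)N2CCN(c3ccc(F)cc3)CC2)cc1` differs from compound 3 only in one place: fluoro in place of methoxy on an aromatic carbon. Going by the values given here, no compound with fluoro at this position has been measured, so the expectation rests on the two steps into compound 3: removing methoxy in favour of chloro or hydrogen would, read backwards, raise the number by the sizes just given. A rise of similar modest size is therefore expected for compound 4, a number 15.6 percentage points higher from compound 3 to compound 4 (beyond the scatter). Compound 4 is estimated at 55%, within 42% to 68%.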

Compound 4, a percentage reported as inhibition, at one concentration (the size of the read-out at that concentration, not a potency): 60.8%
The estimate for compound 4 lay 5.8 percentage points below the measured number; low and high end bracket the measured number.
By their numbers in this assay, from the lowest: compound 3; then compounds 1, 4 and 2 (each within the scatter of the next, the first and the last beyond it).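

In this assay fluoro in place of methoxy gives a number 21.4 percentage points higher from compound 3 to compound 4 (beyond the scatter) and adds a third group that separates from methoxy at this position. Fluoro in place of hydrogen gives a number 1.4 percentage points lower from compound 2 to compound 4 (within the scatter) and fluoro in place of chloro gives a number 9.6 percentage points higher from compound 1 to compound 4 (within the scatter) and so fluoro cannot be told apart from either, although hydrogen and chloro separate from each other. Going by these compounds alone, compound 3 is the only compound beyond the scatter from all three others.

As far as these compounds go, whether an amine or a carboxylic acid on this carbon would fall with compound 3 or with the other three remains open. Nothing at hand says what sets methoxy apart.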